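Chloro in place of hydrogen on compound 1

This account rests on a few compounds, and the source may have more. Where it says the series, first, only, none or still open, it means among the compounds named here.

- compound 1 (`COc1ccc(-c2nc3sc(-c4ccccc4)cn3n2)cc1`) at 35%
- compound 2 (`COc1cc(-c2nc(N)n(CC(=O)Nc3ccc(/C(C)=N\O)cc3)n2)cc(OC)c1OC`) at 15.5%
- compound 3 (`C/C(=N/O)c1ccc(NC(=O)Cn2nc(-c3ccccc3)nc2N)cc1`) at 6.77%

All three were read in a functional assay on CCRF-CEM cells (Homo sapiens) for inhibition, read by sulforhodamine B assay, with a stated time of 48 h, tested at 10 uM (on this read-out lower numbers stand for less inhibition of growth and higher numbers for more inhibition of growth at the one concentration tested), and compound 1 stands highest, with compound 2 and compound 3 lower by gaps beyond the scatter. Compound 4 (`COc1ccc(-c2nc3sc(-c4ccc(Cl)cc4)cn3n2)cc1`) keeps the core of compound 1 and differs in one place: phenyl to 4-chlorophenyl, chloro in place of hydrogen on an aromatic carbon, para to a large group (chloro in place of hydrogen on an aromatic carbon). Among the compounds with values here, no measured pair differs in one place only, so this step in this assay has no direct precedent. A small rise in growth inhibition, not clearly beyond the scatter, is expected as the estimated step (a number 7 percentage points higher from compound 1 to compound 4 (within the scatter)). For compound 4 the expected value is 42% (estimated range 22% to 65%).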

Compound 4, percent growth inhibition at one concentration: 30.5%
Estimate against measurement, compound 4: 11.5 percentage points above, within the range that was stated.
By their numbers in this assay, from the lowest: compounds 3 and 2 (each within the scatter of the next); then compounds 4 and 1 (each within the scatter of the next).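

In this assay, within the data shown here, the change from phenyl to 4-chlorophenyl gives the first step that can be read in one place (a number 4.5 percentage points lower from compound 1 to compound 4 (within the scatter)). At this position, a chloro in place of hydrogen therefore leaves growth inhibition within the scatter, and this single pair separates the two substituents no further. No evidence bearing on this result is available.

As far as these compounds go, whether the position behaves the same way with an amine or a carboxylic acid remains open, as does the outcome of a chloro at another place on the ring.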